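A few compounds are considered here, and "the series" means these few. Any claim that something is new, unique, unknown or untested is made for them only; others in the source may bear on it.

In a functional assay on L02 cells (Homo sapiens) for inhibition, read by Griess assay, with stated times of 1 h and 24 h (on this read-out higher numbers stand for weaker inhibition and lower numbers for stronger inhibition), compound 1 `CCCc1nn(C)c2c(NC3CC3)nc(/C=C/c3nc(C)c(C)nc3C)nc12` gives 706000 nM.
In this assay compound 2 `CCCc1nn(C)c2c(NCc3ccc(F)cc3)nc(CCc3cccnc3)nc12` is recorded only as < 40000 nM, a limit of the assay rather than a number.
In this assay compound 3 `CNc1nc(/C=C/c2ccccc2)nc2ccsc12` is recorded only as > 1000000 nM, again a limit of the assay rather than a number.

Compound 3 thus stands at the limit of > 1000000 nM in this assay, at which 1 of the 3 values shown sits, the weak end of what the three values show, with no exact number behind it. Compound 4 `Brc1cccc(Nc2nc(/C=C/c3ccccc3)nc3ccsc23)c1` differs from compound 3 in a single place: 3-bromophenyl in place of methyl on a nitrogen on an aromatic ring. Among the compounds with values here, no step between two measured compounds is available to set beside this change, so its size and direction can be judged only from the change itself. One expects the change to move compound 4 toward stronger inhibition by a modest amount, while allowing that a step no larger than the usual scatter would not surprise, and that compound 4 may itself return only a limit in this assay. The step from compound 3 to compound 4 that is expected reads an at least 2.0-fold lower number from compound 3 to compound 4 (0.30 log units; that floor lies within the scatter). The estimate for compound 4 in this assay is 500000 nM, with a range from 50000 nM to 2000000 nM.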

Compound 4, half-maximal inhibitory concentration: > 1000000 nM
Compound 4 was reported as a limit; the forecaster's own chance of this, stated with the estimate: 50%; middle value at least 2.0-fold (0.30 log units) away from the limit.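

Compound 3 and compound 4 are both recorded only as limits in this assay, and no step from one to the other can be read: the limit of > 1000000 nM in this assay, at which 2 of the 4 values shown sit.

The compounds shown leave open whether 3-bromophenyl in place of methyl on that nitrogen changes inhibition at all, and by how much.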